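Replacing 3,4-dichlorophenyl with 4-methylphenyl on a shared core

The source may hold more compounds than are shown below. What is called first, only, known or untested is meant among the compounds shown, and "the series" means these compounds.

In a functional assay on L1210 cells (Mus musculus) for antiproliferative activity (on this read-out lower numbers stand for stronger inhibition and higher numbers for weaker inhibition), compound 1 (`COc1cc(C(=O)c2sc(-c3ccc(I)cc3)cc2N)cc(OC)c1OC`) gives 400 nM and compound 2 (`COc1cc(C(=O)c2sc(-c3ccc(Cl)c(Cl)c3)cc2N)cc(OC)c1OC`) gives 260 nM, so these two values lie within the scatter of each other. Compound 3 (`COc1cc(C(=O)c2sc(-c3ccc(C)cc3)cc2N)cc(OC)c1OC`) carries 4-methylphenyl in place of 3,4-dichlorophenyl on an aromatic carbon. Within the data shown here, one measured step bears on this change, at the same place: a 1.5-fold lower number from compound 1 to compound 2 (0.19 log units; within the scatter). Among the measured compounds shown here, with only that small step as a guide, no step beyond the scatter is expected in this assay. The expected step is a 1.1-fold higher number from compound 2 to compound 3 (0.03 log units; within the scatter). For compound 3, the estimate is 280 nM, with an expected range from 100 nM to 750 nM.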

Compound 3, half-maximal inhibitory concentration: 18 nM
Compound 3: middle estimate off by 16-fold (1.19 log units), on the high side, and the stated range ends above it.
By their numbers in this assay, from the lowest: compound 3; then compounds 2 and 1 (each within the scatter of the next).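

At this place on the shared core, the group carried can shift the number in this assay well beyond the scatter, which the earlier swap between 4-iodophenyl and 3,4-dichlorophenyl did not show. The change to 4-methylphenyl gives a 14-fold lower number from compound 2 to compound 3 (1.16 log units; beyond the scatter) and, set against the iodo compound, a 22-fold lower number from compound 1 to compound 3 (1.35 log units; beyond the scatter) on the same shared core. Nothing available explains this large step. The compounds shown leave open whether methyl itself carries the step, and an ethyl or methoxy group in its place would bear on that. An unsubstituted phenyl would show what the methyl group adds.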